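The compounds below may be only part of what the source reports. "The series", "measured", "known", "first", "only" and "open" are said of these compounds alone.

Three compounds have been measured in an assay on CHO cells for displacement of a labelled ligand from adenosine receptor A3 (Homo sapiens), read by scintillation counting, with a stated time of 120 min, tested at 1 uM; a higher number here means more inhibition at the concentration tested (going by the name of the read-out), a lower number less inhibition:
compound 1 `N#Cc1c(N)nc(SCc2ccn[nH]2)c(C#N)c1-c1ccc(OCC2CC2)cc1` gives 6%
compound 2 `N#Cc1c(N)nc2sc(C(N)=O)c(N)c2c1-c1ccc(OCC2CC2)cc1` gives 13%
compound 3 `N#Cc1c(N)nc(SCC(N)=O)c(C#N)c1-c1ccc(OCC2CCC2)cc1` gives 1%

On these numbers compound 1 stands second highest of the three. Compound 3 is nearest, lower by an amount within the scatter, and compound 2 is furthest, higher by an amount that is also within the scatter, so the three read alike and none can be set apart from the others. The step to compound 4 `N#Cc1c(N)nc(SCC(=O)NO)c(C#N)c1-c1ccc(OCC2CC2)cc1` alters one group: hydroxycarbamoyl in place of 1H-pyrazol-5-yl on a saturated chain carbon bound to a sulfur. Among the measured compounds shown here, no measured pair shows this change, and every number seen so far is low. The step is therefore expected to be a number 1 percentage points lower from compound 1 to compound 4 (within the scatter), nothing beyond the scatter in either direction. Compound 4 is estimated at 5%, with a range from -5% to 15%.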

Compound 4, a percentage reported as inhibition, at one concentration (the size of the read-out at that concentration, not a potency): 31%
Beside the measured number, compound 4's estimate is 26 percentage points below it; the measured number lies above the stated range.
By their numbers in this assay, from the lowest: compounds 3, 1 and 2 (each within the scatter of the next, the first and the last beyond it); then compound 4.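

In this assay, hydroxycarbamoyl in place of 1H-pyrazol-5-yl on a saturated chain carbon bound to a sulfur gives a number 25 percentage points higher from compound 1 to compound 4 (beyond the scatter). Among the compounds shown here, this shows that the read-out responds to a change at this position, which the earlier compounds, differing in more than one place, could not show. No evidence bears on what lies behind the step.

From the compounds shown here alone, whether a carboxylic acid or a methyl ester in the same place would read like compound 4 remains open. So does how compound 4 behaves at other concentrations, since a single-concentration reading gives no potency.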